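Cyclohexyl for tert-butyl in a cytotoxic hydroxamate series

This account rests on a few compounds, and the source may have more. Where it says the series, first, only, none or still open, it means among the compounds named here.

Measured in a functional assay on CAL-27 cells (Homo sapiens) for cytotoxicity, read by MTT assay, with a stated time of 72 h; on this read-out higher numbers stand for weaker inhibition and lower numbers for stronger inhibition:
- compound 1 `CCCCNC(=O)CN(CCCCCC(=O)NO)C(=O)c1ccc(N(C)C)cc1` gives 1870 nM
- compound 2 `O=C(CCCCCN(C(=O)c1ccccc1)C1(C(=O)NC2CCCCC2)CCCCC1)NO` gives 44100 nM
- compound 3 `CC(C)(C)NC(=O)CN(CCCCCC(=O)NO)C(=O)c1ccccc1` gives 16700 nM

Compound 3 holds the middle place of the three numbers. It lies closer to compound 2 than to compound 1, and both gaps are beyond the scatter. Compound 4 `O=C(CCCCCN(CC(=O)NC1CCCCC1)C(=O)c1ccccc1)NO` is the next to be read. It has cyclohexyl in place of tert-butyl on an amide-type nitrogen and is otherwise the same as compound 3.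

Among the measured compounds shown here, no two measured compounds differ in one place only, so the series gives no direct size for this change. Compound 2 also carries cyclohexyl on an amide-type nitrogen and gives 44100 nM in this assay, but it differs from compound 4 elsewhere too, which makes it a weak guide. No step beyond the scatter is expected, and the estimated step is a 1.4-fold lower number from compound 3 to compound 4 (0.14 log units; within the scatter) in this assay, with only a slight lean toward a lower number. Compound 4 is expected at an estimated 12000 nM in a range from 5000 nM to 30000 nM in this assay.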

Compound 4, half-maximal inhibitory concentration: 3800 nM
Compound 4: middle estimate off by 3.2-fold (0.50 log units), on the high side; measured number outside the range, below it.
By their numbers in this assay, from the lowest: compound 1; then compound 4; then compound 3; then compound 2.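

In this assay, among the compounds shown here, compounds 3 and 4 form the first pair that differ in one place only, and they give this position a measured size: cyclohexyl in place of tert-butyl on an amide-type nitrogen gives a 4.4-fold lower number from compound 3 to compound 4 (0.64 log units; beyond the scatter). The read-out at this position therefore responds to the group on the amide-type nitrogen, and here the six-membered carbon ring with 6 heavy atoms gives the lower number, though a single pair sets no trend. Nothing at hand accounts for the size of this step.

Open, on these data alone, is whether the ring or the carbon count goes with the lower number, which cyclopentyl, phenyl or a straight hexyl chain on this nitrogen would help to separate. Also open, as far as these compounds go, is whether the same step holds on the cores of compound 1 and compound 2.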